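Changing the thiophene group: compound 3 to compound 4

A few compounds are considered here, and "the series" means these few. Any claim that something is new, unique, unknown or untested is made for them only; others in the source may bear on it.

- compound 1 `O=C1NCCC12CCN(c1c(Cl)cncc1-c1ccco1)CC2`: 940 nM
- compound 2 `O=C1NCCC12CCN(c1c(Cl)cncc1-c1ccsc1)CC2`: 190 nM
- compound 3 `Cc1ccc(-c2cncc(Cl)c2N2CCC3(CCNC3=O)CC2)s1`: 650 nM

The standing of compound 3 in a functional assay on MV4-11 cells (Homo sapiens) for inhibition, read by resazurin assay, with a stated time of 72 h (a higher number here means a weaker inhibitor of growth, a lower number a stronger inhibitor of growth), is set by two steps: a 1.4-fold lower number from compound 1 to compound 3 (0.16 log units; within the scatter), and a 3.4-fold higher number from compound 2 to compound 3 (0.53 log units; beyond the scatter). Compound 4 `O=Cc1sccc1-c1cncc(Cl)c1N1CCC2(CCNC2=O)CC1` carries 2-formylthiophen-3-yl in place of 5-methylthiophen-2-yl on an aromatic carbon. The nearest measured group is the thiophen-3-yl of compound 2, and a 4.9-fold lower number from compound 1 to compound 2 (0.69 log units; beyond the scatter) also favours it. For the measured compounds named here, no measured compound carries the formyl group, so only a small drop in this assay is expected, probably none beyond the scatter. The estimated change is a 1.6-fold lower number from compound 3 to compound 4 (0.21 log units; within the scatter). For compound 4 the expected value is 400 nM, with a range of 130 nM to 1200 nM.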

Compound 4, concentration for 50% growth inhibition: 28700 nM
Beside the measured number, compound 4's estimate is 72-fold (1.86 log units) below it, and the stated range ends below it.
By their numbers in this assay, from the lowest: compound 2; then compounds 3 and 1 (each within the scatter of the next); then compound 4.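

In this assay adding a formyl group to the thiophen-3-yl group costs far more than any earlier change at this aromatic carbon (a 150-fold higher number from compound 2 to compound 4 (2.18 log units; beyond the scatter)). The 2-formylthiophen-3-yl group also falls well behind the other two groups (a 44-fold higher number from compound 3 to compound 4 (1.64 log units; beyond the scatter); a 31-fold higher number from compound 1 to compound 4 (1.48 log units; beyond the scatter)), so this position does not accept every substituted thiophene. Nothing available explains this loss. Still open, going by these compounds, is whether a hydroxymethyl, a carboxylic acid or an aminomethyl group in place of the formyl would lose as much, or whether the loss is particular to the formyl group.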